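A few compounds are considered here, and "the series" means these few. Any claim that something is new, unique, unknown or untested is made for them only; others in the source may bear on it.

Of the compounds shown here, three built on one shared core have been measured. Compound 1 `COc1ccc(C(=O)/C(=C/c2ccc(Cl)cc2Cl)CCOC(C)=O)cc1` gives 83400 nM in a functional assay on MCF7 cells (Homo sapiens) for inhibition, read by XTT assay, with a stated time of 48 h; on this read-out lower numbers stand for stronger inhibition and higher numbers for weaker inhibition. Compound 2 `COc1ccc(C(=O)/C(=C/c2ccc(Cl)cc2Cl)CC(C)OC(C)=O)cc1` reaches only a limit of this assay and is recorded as > 100000 nM. Compound 3 `COc1ccc(C(=O)/C(=C/C2CCCCC2)CC(C)OC(C)=O)cc1` likewise stands at a limit, with > 100000 nM. Compound 2 therefore stands where no number is known, only (the limit of > 100000 nM in this assay, at which 2 of the 3 values shown sit). Of the two measured steps, an at least 1.1-fold higher number from compound 1 to compound 2 (0.07 log units; that floor lies within the scatter) adds a methyl on the chain carbon that carries the acetoxy oxygen, and a step that the two limits leave unreadable from compound 2 to compound 3 swaps the aryl group on the double bond; neither removes the acetoxy itself.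

Compound 4 `COc1ccc(C(=O)/C(=C/c2ccc(Cl)cc2Cl)CC(C)C)cc1` differs from compound 2 by methyl in place of acetoxy on a saturated chain carbon bound to two saturated chain carbons. Within the data shown here, no measured step touches this change directly, and the two that sit nearest run from a weak number into a limit or from one limit to another, so their sizes give no readable direction. Compound 4 is therefore expected to stay in the same weak region as compound 2, with a step of a number no higher from compound 2 to compound 4 (the limit leaves the size open) that is not expected to exceed the scatter. On that footing compound 4 is estimated at 100000 nM in this assay, within a range from 30000 nM to 300000 nM, and a limit rather than a number is a likely outcome.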

Compound 4, half-maximal inhibitory concentration: > 100000 nM
Compound 4: no number, only a limit; the forecaster's own chance of this, stated with the estimate: 60%; the middle value lies on the limit itself.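

In this assay, among these compounds, compound 4 gives > 100000 nM, which is a limit of the assay and not a number, so taking away the acetoxy, the one group that compound 1, compound 2 and compound 3 all carry at this part of the chain, does not yield a readable value. The steps that join two limits cannot be read, and the only readable one, with isopropyl in place of acetoxymethyl on a saturated chain carbon bound to a double-bonded chain carbon, is an at least 1.1-fold higher number from compound 1 to compound 4 (0.07 log units; that floor lies within the scatter), which does not separate the two compounds. With methyl in place of acetoxy, compound 4 joins compound 2 and compound 3 at the same limit: the limit of > 100000 nM in this assay, at which 3 of the 4 values shown sit.

The compounds shown leave open whether an amine, a carboxylic acid or a longer chain on this saturated chain carbon would give a number rather than a limit in this assay. Going by these compounds, the order of compound 2, compound 3 and compound 4 among themselves also stays unknown, as each of the three is recorded only as a limit.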